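Working notes: methoxy step from compound 2 to compound 3

The source may hold more compounds than are shown below. What is called first, only, known or untested is meant among the compounds shown, and "the series" means these compounds.

compound 1 `Cc1ccc([S@+]([O-])C2=C(Cl)C(=O)C=CC2=O)cc1`: "not active" (no number reported)
compound 2 `Cc1ccc([S@+]([O-])C2=CC(=O)C=CC2=O)cc1`: 300 nM

Among the measured compounds shown here, in a functional assay on SNU-475 cells (Homo sapiens) for inhibition, read by sulforhodamine B assay, with a stated time of 72 h (a lower number here means a stronger inhibitor, a higher number a weaker inhibitor), compound 2 gives 300 nM, the only number so far. Compound 1 is reported as "not active" (no number reported), with no number attached. Still unmeasured is compound 3 `COC1=CC(=O)C([S@@+]([O-])c2ccc(C)cc2)=CC1=O`, which differs from compound 2 as follows: methoxy in place of hydrogen on a double-bonded ring carbon. For the measured compounds named here, no step between measured compounds is available to size this change. With compound 1 at "not active" (no number reported) and compound 2 at 300 nM, a weaker value is the more likely direction, with a moderate loss beyond the scatter expected rather than complete loss of activity. In this assay, the estimated value for compound 3 is 700 nM, with an expected range of 200 nM to 3000 nM. This estimate means an expected 2.3-fold higher number from compound 2 to compound 3 (0.37 log units; beyond the scatter).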

Compound 3, half-maximal inhibitory concentration: 9000 nM
The estimate for compound 3 lay 13-fold (1.11 log units) below the measured number, outside the stated range (above it).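

In this assay, among the compounds shown here, methoxy in place of hydrogen on a double-bonded ring carbon gives a 30-fold higher number from compound 2 to compound 3 (1.48 log units; beyond the scatter) and so puts a first size on a change. This carbon, three ring bonds from the ring atom that bears a group of 9 heavy atoms, accepts methoxy only with a large loss, though compound 3 still returns a number rather than a "not active" report. Nothing measured here accounts for the size of this step.

From the compounds shown here alone, only hydrogen and methoxy are compared at this carbon, so it remains open whether the loss is specific to methoxy or extends to other groups. A fluorine atom, an amine or a longer ethoxy chain at the same carbon would help to separate these possibilities.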